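Adding a Methoxy Group to Compound 3

This account rests on a few compounds, and the source may have more. Where it says the series, first, only, none or still open, it means among the compounds named here.

Compound 3 `COc1ccc(C(=CC#N)c2cc(OC)cc(OC)c2)cc1` gives 1.2 nM in a functional assay on HCT-116 cells (Homo sapiens) for cytotoxicity, read by scintillation counting and thymidine incorporation, with a stated time of 72 h (on this read-out higher numbers stand for weaker inhibition and lower numbers for stronger inhibition), the lowest of the three numbers in hand. Compound 2 `COc1cc(OC)cc(C(=CC#N)c2ccc(OC)c(O)c2)c1` gives 2.5 nM in this assay. The step of a 2.1-fold lower number from compound 2 to compound 3 (0.32 log units; beyond the scatter) shows that hydrogen in place of hydroxy on an aromatic carbon changed little. Compound 1 `CC=C(c1cc(OC)cc(OC)c1)c1ccc(OC)c(OC)c1` gives 480 nM in this assay, far weaker, but it differs from compound 3 in more than one place, so no single step can be read from that gap. Compound 4 `COc1cc(OC)cc(C(=CC#N)c2ccc(OC)c(OC)c2)c1` carries methoxy in place of hydrogen on an aromatic carbon. The step from compound 2 to compound 3 is the only measured one that bears on this change, and it was modest. Compound 4 is therefore expected to shift only modestly, by a 1.7-fold higher number from compound 3 to compound 4 (0.22 log units; within the scatter). Compound 4 is estimated at 2 nM, within 0.7 nM to 6 nM.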

Compound 4, half-maximal inhibitory concentration: 18 nM
Compound 4: middle estimate off by 9.0-fold (0.95 log units), on the low side, outside the stated range (above it).
By their numbers in this assay, from the lowest: compound 3; then compound 2; then compound 4; then compound 1.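

In this assay, methoxy on this aromatic carbon proved far from neutral, giving a 15-fold higher number from compound 3 to compound 4 (1.18 log units; beyond the scatter), and methylating the hydroxy group at the same place gave a 7.2-fold higher number from compound 2 to compound 4 (0.86 log units; beyond the scatter), so hydrogen, hydroxy and methoxy separate clearly here. The change on the chain, cyano in place of methyl, still gave a 27-fold lower number from compound 1 to compound 4 (1.43 log units; beyond the scatter) with this methoxy present. Nothing measured here accounts for the loss at this position. Going by these compounds, whether an amine or a fluorine on this aromatic carbon would stand nearer compound 3 or compound 4 remains open. So does the size of the cyano step with hydrogen at this place.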